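Chloro in Place of Fluoro: Expected Binding of Compound 4

A few compounds are considered here, and "the series" means these few. Any claim that something is new, unique, unknown or untested is made for them only; others in the source may bear on it.

Compound 1 `CC(C)[C@H](NC(=O)CCN(C)C)c1cccc(F)c1N1CCN(C(=O)[C@@H]2CN(C(C)C)C[C@H]2c2cc(F)c(F)c(F)c2)CC1` gives 250 nM in an assay on HEK293 cells for displacement of a labelled ligand from Melanocortin receptor 4 (Homo sapiens); a higher number here means a weaker inhibitor, a lower number a stronger inhibitor.
Compound 2 `Cc1cccc([C@@H]2CN(C(C)C)C[C@H]2C(=O)N2CCN(c3c(F)cccc3[C@@H](NC(=O)CCN(C)C)C(C)C)CC2)c1` gives 470 nM in this assay.
Compound 3 `CC(C)[C@H](NC(=O)CCN(C)C)c1cccc(F)c1N1CCN(C(=O)[C@@H]2CN(C(C)C)C[C@H]2c2cccc(F)c2)CC1` gives 560 nM in this assay.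

Compound 3 has the highest of the three numbers: its nearest neighbour is compound 2, a step within the scatter, a 1.2-fold higher number from compound 2 to compound 3 (0.08 log units; within the scatter), while its gap to compound 1 goes beyond the scatter, a 2.2-fold higher number from compound 1 to compound 3 (0.35 log units; beyond the scatter). Compound 4 `CC(C)[C@H](NC(=O)CCN(C)C)c1cccc(F)c1N1CCN(C(=O)[C@@H]2CN(C(C)C)C[C@H]2c2cccc(Cl)c2)CC1` differs from compound 3 in one place: chloro in place of fluoro on an aromatic carbon.

Going by the values given here, two measured steps bear on this change. The swap of methyl for fluoro at the same aromatic carbon, a 1.2-fold higher number from compound 2 to compound 3 (0.08 log units; within the scatter), stayed within the scatter. Removing two fluorines from the same ring, a 2.2-fold higher number from compound 1 to compound 3 (0.35 log units; beyond the scatter), gave only a modest rise. Chloro, like methyl and fluoro, is a single heavy atom on that carbon, so no step beyond the scatter is expected in this assay for compound 4, and the estimated step is a 1.2-fold lower number from compound 3 to compound 4 (0.09 log units; within the scatter). Compound 4 is therefore expected to give about 450 nM, within a range of 200 nM to 1100 nM.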

Compound 4, inhibition constant: 370 nM
The estimate for compound 4 lay 1.2-fold (0.09 log units) above the measured number; measured number inside the range.
By their numbers in this assay, from the lowest: compounds 1, 4, 2 and 3 (each within the scatter of the next, the first and the last beyond it).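

In this assay, chloro now joins fluoro and methyl on this aromatic carbon, meta to a large group, with no step beyond the scatter among the three (a 1.5-fold lower number from compound 3 to compound 4 (0.18 log units; within the scatter); a 1.3-fold lower number from compound 2 to compound 4 (0.10 log units; within the scatter)). The earlier gap beyond the scatter between 3-fluorophenyl and 3,4,5-trifluorophenyl (a 2.2-fold higher number from compound 1 to compound 3 (0.35 log units; beyond the scatter)) does not carry over to 3-chlorophenyl, which stays within the scatter of 3,4,5-trifluorophenyl (a 1.5-fold higher number from compound 1 to compound 4 (0.17 log units; within the scatter)), so one fluoro-to-chloro swap is enough to remove that separation. No available evidence accounts for these steps.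

The compounds shown leave open whether a methoxy group, a trifluoromethyl group or an amine on this carbon would also stay within the scatter of these compounds. They also leave open how 3,4,5-trichlorophenyl would compare with 3,4,5-trifluorophenyl.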